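The compounds below may be only part of what the source reports. "The series", "measured", "known", "first", "only" and "open" are said of these compounds alone.

Measured in a physicochemical assay for solubility; a higher number here means a more soluble compound, a lower number a less soluble compound
- compound 1 `CC(C)(O)CCN1CCC(NS(=O)(=O)c2cc(S(=O)(=O)c3ccccc3)ccc2C(F)(F)F)CC1` gives 50000 nM
- compound 2 `CC(C)(C)OC(=O)N1CCC[C@@H]1C(=O)N1CCC(NS(=O)(=O)c2cc(S(=O)(=O)c3ccccc3)ccc2C(F)(F)F)CC1` gives 25000 nM
- compound 3 `CC(C)(C)OC(=O)N1CC[C@H](C(=O)N2CCC(NS(=O)(=O)c3cc(S(=O)(=O)c4ccccc4)ccc3C(F)(F)F)CC2)C1` gives 25000 nM

Compound 3 at 25000 nM stands level with compound 2 and within the scatter of compound 1. Among the compounds with values here, compound 4 `O=C(CC1CCNCC1)N1CCC(NS(=O)(=O)c2cc(S(=O)(=O)c3ccccc3)ccc2C(F)(F)F)CC1` has (piperidin-4-yl)methyl in place of 1-(tert-butoxycarbonyl)pyrrolidin-3-yl on a carbonyl carbon as its one change. Within the data shown here, the only measured step of no change at the digits printed from compound 2 to compound 3 (within the scatter) bears on this loosely, since no measured step replaces that group outright. With so narrow a spread of values, no move beyond the scatter is expected in this assay and any lean is upward. The expected step is a 1.4-fold higher number from compound 3 to compound 4 (0.15 log units; within the scatter) and it stays within the scatter. Compound 4 is estimated at 35000 nM with an expected range from 15000 nM to 80000 nM in repeat measurements.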

Compound 4, solubility: 100000 nM
The estimate for compound 4 lay 2.9-fold (0.46 log units) below the measured number; the measured number lies above the stated range.
By their numbers in this assay, from the lowest: compounds 2, 3, 1 and 4 (each within the scatter of the next, the first and the last beyond it).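

In this assay, (piperidin-4-yl)methyl on a carbonyl carbon gives the first moves beyond the scatter: a 4.0-fold higher number from compound 3 to compound 4 (0.60 log units; beyond the scatter) and a 4.0-fold higher number from compound 2 to compound 4 (0.60 log units; beyond the scatter), each replacing a tert-butoxycarbonyl-bearing pyrrolidinyl group. Against the 3-hydroxy-3-methylbutyl compound, the step is a 2.0-fold higher number from compound 1 to compound 4 (0.30 log units; within the scatter), so this comparison does not separate the two. No measured evidence accounts for these steps. The change alters ring size, heavy-atom count and hydrogen-bond donors together, so the part responsible remains unresolved. A (1-(tert-butoxycarbonyl)piperidin-4-yl)methyl group on the same carbonyl carbon would bear directly on this.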